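A few compounds are considered here, and "the series" means these few. Any claim that something is new, unique, unknown or untested is made for them only; others in the source may bear on it.

Within the data shown here, compound 2 `CC(C)c1ccc2c(c1)[n+]([O-])c(NCCN(C)C)n[n+]2[O-]` is the one compound that shows a plain number in a physicochemical assay for solubility, in the presence of a further agent that is not named here (on this read-out lower numbers stand for lower solubility and higher numbers for higher solubility), where compound 2 gives 42000000 nM. Compound 1 `Cc1ccc2c(c1)[n+]([O-])c(NCCN(C)C)n[n+]2[O-]` differs from it only in carrying a methyl in place of an isopropyl on an aromatic carbon. In this assay compound 1 gives > 51000000 nM, which is a limit of the assay rather than a number. The step of an at least 1.2-fold lower number from compound 1 to compound 2 (0.08 log units; that floor lies within the scatter) is thus known only as a floor. Compound 3 `CN(C)CCNc1n[n+]([O-])c2ccc(C(C)(C)C)cc2[n+]1[O-]` has not yet been measured. Its change from compound 2 is methyl in place of hydrogen on a saturated chain carbon bound to an aromatic carbon and two saturated chain carbons. Among the measured compounds shown here, the one measured step, isopropyl replacing methyl, is the only evidence bearing on adding a further methyl to that same chain, and it points, if anywhere, toward a somewhat lower number. For compound 3 a step of a 1.4-fold lower number from compound 2 to compound 3 (0.15 log units; within the scatter) is therefore expected, hardly beyond the scatter. Compound 3 is estimated at 30000000 nM, between 15000000 nM and 60000000 nM.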

Compound 3, solubility: 38000000 nM
For compound 3 the middle estimate is 1.3-fold (0.10 log units) below the measured one; the range from low to high includes it.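

Swapping isopropyl for tert-butyl on the same aromatic carbon gives a 1.1-fold lower number from compound 2 to compound 3 (0.04 log units; within the scatter), the first step here with a plain number at both ends, and in this assay it cannot be told apart from repeat-measurement noise. So, on this read-out, the extra methyl on that saturated chain carbon makes no difference that these two values can show. The wider change from methyl to tert-butyl gives an at least 1.3-fold lower number from compound 1 to compound 3 (0.12 log units; that floor lies within the scatter), which is again only a floor.

Compound 1 stands at a limit, not a number, so the full size of that wider step stays unknown: the limit of > 51000000 nM in this assay, at which 1 of the 3 values shown sits.

Every group shown at this aromatic carbon is built only of carbon and hydrogen, so an amine, a carboxylic acid or a longer chain there remains an open case. On these data alone, whether any of these would move the read-out beyond the usual scatter also stays open.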